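Swapping the carbamate ester group in a kinase inhibitor series

A few compounds are considered here, and "the series" means these few. Any claim that something is new, unique, unknown or untested is made for them only; others in the source may bear on it.

Of the compounds shown here, three sharing one core have been tested in an assay for inhibition of serine/threonine-protein kinase PAK 4 (Homo sapiens), read by FRET and Z'-LYTE, with a stated time of 60 min, tested at 0.5 uM, in the presence of a further agent that is not named here; on this read-out lower numbers stand for a weaker effect and higher numbers for a stronger effect at the one concentration tested. Compound 2 `COC(=O)N1CCN(C(=O)c2nc(Nc3cc(C4CC4)[nH]n3)c3cc(Cl)ccc3n2)C[C@H]1C` gives 73.9%, the highest number of the three. Compound 1 `C[C@@H]1CN(C(=O)c2nc(Nc3cc(C4CC4)[nH]n3)c3cc(Cl)ccc3n2)CCN1C(=O)OCc1ccccc1` gives 4.4%, and compound 3 `CC(OC(=O)C(C)C)OC(=O)N1CCN(C(=O)c2nc(Nc3cc(C4CC4)[nH]n3)c3cc(Cl)ccc3n2)C[C@H]1C` gives 9.4%. Compound 3 thus stands second highest of the three, close to compound 1 and far from compound 2: the step of a number 5 percentage points higher from compound 1 to compound 3 (within the scatter) is within the scatter, while a number 64.5 percentage points lower from compound 2 to compound 3 (beyond the scatter) is large, as is a number 69.5 percentage points higher from compound 1 to compound 2 (beyond the scatter). Only the small methyl on the oxygen next to the carbonyl group has gone with a high number here.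

Compound 4 `C[C@@H]1CN(C(=O)c2nc(Nc3cc(C4CC4)[nH]n3)c3cc(Cl)ccc3n2)CCN1C(=O)OCC(Cl)(Cl)Cl` is not yet measured. It differs from compound 3 in one place: 2,2,2-trichloroethyl in place of 1-((isopropylcarbonyl)oxy)ethyl on an oxygen next to a carbonyl group. The entering group is smaller than the one that leaves, though larger than the methyl of compound 2, so it falls between the two cases already seen. The step of a number 64.5 percentage points lower from compound 2 to compound 3 (beyond the scatter) argues that a smaller group may bring the number back up, while a number 5 percentage points higher from compound 1 to compound 3 (within the scatter) shows that two larger groups behaved alike. A moderate rise is therefore expected for compound 4, estimated as a number 20.6 percentage points higher from compound 3 to compound 4 (beyond the scatter), giving an expected value of 30% with a range from 5% to 70%.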

Compound 4, a percentage reported as inhibition, at one concentration (the size of the read-out at that concentration, not a potency): -1.5%
For compound 4 the middle estimate is 31.5 percentage points above the measured one; measured number outside the range, below it.
By their numbers in this assay, from the lowest: compounds 4, 1 and 3 (each within the scatter of the next, the first and the last beyond it); then compound 2.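

Heavy atom count does not predict the outcome at this position: the 2,2,2-trichloroethyl group of compound 4 has 5 heavy atoms against 8 for the 1-((isopropylcarbonyl)oxy)ethyl group it replaces, yet the result is a number 10.9 percentage points lower from compound 3 to compound 4 (beyond the scatter), a modest step that brings no recovery towards compound 2. The trichloromethyl group, which has no ring, also gives a number 5.9 percentage points lower from compound 1 to compound 4 (within the scatter) in place of the phenyl, while in place of hydrogen it gives a number 75.4 percentage points lower from compound 2 to compound 4 (beyond the scatter), so among these four compounds the methyl alone goes with a high number, and three quite different larger groups, one with a ring, one with an ester and one with chlorine, all go with low numbers. Nothing available here explains these numbers.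

The compounds shown leave open how far the group can grow beyond methyl before the number falls, a question that a plain ethyl or a 2-chloroethyl group would address. They also leave open whether the oxygen next to the carbonyl group matters, which an amine nitrogen in its place would test.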